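The source may hold more compounds than are shown below. What is called first, only, known or untested is meant among the compounds shown, and "the series" means these compounds.

In an ADME assay on liver (Homo sapiens) for metabolic stability, using microsomes (a lower number here means that the compound disappears faster, a higher number that the compound lasts longer), compound 3 `COc1cnc(O[C@@H]2C[C@@H](C(=O)N[C@]3(C(=O)NS(=O)(=O)C4CC4)C[C@H]3C3CC3)N(C(=O)[C@@H](NC(=O)OC3CCCC3)C(C)(C)C)C2)c2cc(Cl)ccc12` gives 0.65 h. That places it in the middle of the three measured compounds: compound 1 `COc1cnc(O[C@@H]2C[C@@H](C(=O)N[C@]3(C(=O)NS(=O)(=O)C4CC4)C[C@H]3C(C)C)N(C(=O)[C@@H](NC(=O)OC(C)(C)C)C(C)(C)C)C2)c2cc(Cl)ccc12` has the highest number, 1.38 h, and compound 2 `C=C(C)[C@@H]1C[C@]1(NC(=O)[C@@H]1C[C@@H](Oc2ncc(OC)c3ccc(Cl)cc23)CN1C(=O)[C@@H](NC(=O)OC(C)(C)C)C(C)(C)C)C(=O)NS(=O)(=O)C1CC1` has the lowest, 0.0833 h.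

The next compound, compound 4 `COc1cnc(O[C@@H]2C[C@@H](C(=O)N[C@]3(C(=O)NS(=O)(=O)C4CC4)C[C@H]3C3CC3)N(C(=O)[C@@H](NC(=O)O[C@H](C)C(F)(F)F)C(C)(C)C)C2)c2cc(Cl)ccc12`, keeps the structure of compound 3 except for one group: 1-(trifluoromethyl)ethyl in place of cyclopentyl on an oxygen next to a carbonyl group. 1-(trifluoromethyl)ethyl in place of cyclopentyl on an oxygen next to a carbonyl group The ring of carbon atoms is therefore lost, and the incoming group brings a defined stereocentre.

Among the measured compounds shown here, only one single-place change has been measured so far: a 17-fold lower number from compound 1 to compound 2 (1.22 log units; beyond the scatter). It swaps isopropyl for 1-methylethenyl on a saturated ring carbon, so it does not involve the oxygen where compound 4 differs. It shows that one small change can move the half-life a long way in these compounds, but it gives neither a size nor a direction for this new change.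

For the measured compounds named here, with no measured step at this place, a step beyond the scatter is not expected, and any drift in this assay could go either way, with a slight upward lean as a tentative guess. The estimated change is a 1.3-fold higher number from compound 3 to compound 4 (0.12 log units; within the scatter). The expected half-life of compound 4 is 0.85 h, within an estimated range of 0.3 h to 2.3 h.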

Compound 4, half-life: 2.12 h
Beside the measured number, compound 4's estimate is 2.5-fold (0.40 log units) below it, within the range that was stated.
By their numbers in this assay, from the lowest: compound 2; then compound 3; then compounds 1 and 4 (each within the scatter of the next).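

In this assay, among the compounds shown here, replacing cyclopentyl with 1-(trifluoromethyl)ethyl on an oxygen next to a carbonyl group gives a 3.3-fold higher number from compound 3 to compound 4 (0.51 log units; beyond the scatter) and provides the first measured step at this place. For the compounds shown here, the group on this oxygen therefore affects the half-life, whereas the only earlier step, a 17-fold lower number from compound 1 to compound 2 (1.22 log units; beyond the scatter), came from a change on a saturated ring carbon and lowered the number. No measurement here separates the parts of the exchange, so the rise belongs to the whole swap and cannot be assigned to the loss of the ring, the three fluorine atoms or the defined stereocentre.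

The compounds shown leave open whether an open chain of carbon atoms, such as a longer alkyl chain without fluorine, would give a similar half-life, and whether a chain ending in an amine would be tolerated in this assay. They also leave open whether the mirror-image form of 1-(trifluoromethyl)ethyl would behave the same way, and whether this exchange would raise the number to a similar extent on a core carrying isopropyl instead of cyclopropyl.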